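From 2-chlorophenyl to pentyl on compound 3

This account rests on a few compounds, and the source may have more. Where it says the series, first, only, none or still open, it means among the compounds named here.

Values in a functional assay on cells (T-cell line, Homo sapiens) for inhibition; a higher number here means a weaker inhibitor, a lower number a stronger inhibitor:
Compound 1 `COc1ccc(CCCN2CCC(COCc3ccccc3)CC2)cc1`: 2100 nM
Compound 2 `COc1ccc(CCCN2CCC(COCc3ccc(Cl)c(Cl)c3)CC2)cc1`: 200 nM
Compound 3 `Clc1ccccc1CCCN1CCC(COC(c2ccccc2)c2ccccc2)CC1`: 800 nM

Compound 3 stands between compound 2 and compound 1 on these numbers, and its gap to each lies beyond the scatter. Compound 4 `CCCCCCCCN1CCC(COC(c2ccccc2)c2ccccc2)CC1` departs from compound 3 in one place: pentyl in place of 2-chlorophenyl on a saturated chain carbon, three bonds along the chain from an amine nitrogen in a ring. Going by the values given here, no measured step covers this change. The only one, an 11-fold lower number from compound 1 to compound 2 (1.02 log units; beyond the scatter), replaces a different group, so it shows only that a single replacement can move this assay substantially. Its size and direction cannot be carried over, so no step beyond the scatter is expected, though the uncertainty is wide. The expected step is a 1.3-fold higher number from compound 3 to compound 4 (0.10 log units; within the scatter). For compound 4 the estimated value is 1000 nM, with a range of 300 nM to 3500 nM.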

Compound 4, half-maximal inhibitory concentration: 700 nM
The estimate for compound 4 lay 1.4-fold (0.15 log units) above the measured number, and the stated range covers the measured number.
By their numbers in this assay, from the lowest: compound 2; then compounds 4 and 3 (each within the scatter of the next); then compound 1.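

In this assay, the move from 2-chlorophenyl to pentyl on a saturated chain carbon, three bonds along the chain from an amine nitrogen in a ring, gives a 1.1-fold lower number from compound 3 to compound 4 (0.06 log units; within the scatter). On this core, then, the aromatic ring and its chlorine can be exchanged for a pentyl with no ring and the number stays within the scatter. Nothing at hand explains why the two groups read alike.

Going by these compounds, whether a shorter chain such as propyl, or a chain ending in a hydroxyl group, would read alike remains open. So does whether pentyl would hold its place on the core of compound 2.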